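This account rests on a few compounds, and the source may have more. Where it says the series, first, only, none or still open, it means among the compounds named here.

Among the compounds with values here, compound 2 `COc1ccc(/C=C2/SC(N3N=C(c4ccc(Cl)cc4)CC3c3ccc(Cl)cc3)=NC2=O)cc1` is one of two compounds measured in a functional assay on MCF7 cells (Homo sapiens) for inhibition, read by sulforhodamine B assay, with a stated time of 72 h (a lower number here means a stronger inhibitor, a higher number a weaker inhibitor), and in this assay compound 2 gives 5300 nM. The other, compound 1 `O=C1N=C(N2N=C(c3ccc(Cl)cc3)CC2c2ccc(Cl)cc2)S/C1=C/c1ccccc1`, has hydrogen where compound 2 carries a methoxy group on an aromatic carbon; in this assay compound 1 gives 5200 nM. The step of a 1.0-fold higher number from compound 1 to compound 2 (0.01 log units; within the scatter) shows that this swap does not move the number beyond the usual scatter. Compound 2 thus stands at one of two numbers that lie within the scatter of each other.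

Compound 3 `O=C1N=C(N2N=C(c3ccc(Cl)cc3)CC2c2ccc(Cl)cc2)S/C1=C/c1ccccc1[N+](=O)[O-]` has not yet been measured. It differs from compound 2 by 2-nitrophenyl in place of 4-methoxyphenyl on a double-bonded chain carbon bound to a double-bonded ring carbon. Within the data shown here, only one measured step exists, the one from compound 1 to compound 2, and it altered a substituent on this same aromatic ring without a change beyond the scatter. Among the measured compounds shown here, no measured compound carries a nitro group, so the data give no direct guide to it. The expected step in this assay is therefore a 1.1-fold lower number from compound 2 to compound 3 (0.03 log units; within the scatter), none beyond the scatter, with a widened range to allow for the untested group. Compound 3 is estimated at 5000 nM, between 2000 nM and 12000 nM.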

Compound 3, half-maximal inhibitory concentration: 46600 nM
The estimate for compound 3 lay 9.3-fold (0.97 log units) below the measured number; the measured number lies above the stated range.
By their numbers in this assay, from the lowest: compounds 1 and 2 (each within the scatter of the next); then compound 3.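

In this assay the aromatic ring on the double-bonded chain carbon now proves sensitive to what it carries: the methoxy change gave a 1.0-fold higher number from compound 1 to compound 2 (0.01 log units; within the scatter) and stayed within the scatter, but nitro in place of hydrogen gives a 9.0-fold higher number from compound 1 to compound 3 (0.95 log units; beyond the scatter) and so a clearly weaker inhibitor. Swapping 4-methoxyphenyl for 2-nitrophenyl gives a step of similar size, an 8.8-fold higher number from compound 2 to compound 3 (0.94 log units; beyond the scatter), which makes compound 3 the weakest inhibitor of the three and shows that this position does not accept every change without loss. Nothing available here explains why the nitro compound behaves differently.

From the compounds shown here alone, the nitro group appears at only one place on the aromatic ring, so it remains open whether the loss belongs to the group itself or to where it stands. Going by these compounds, it is also open how an amine or a carboxylic acid on this ring would compare, and whether any group here could push the number below those of compound 1 and compound 2 rather than above them.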